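Swapping the sulfonamide cap: from cyanopyrrolidine to ethynylcyclopropyl

The source may hold more compounds than are shown below. What is called first, only, known or untested is meant among the compounds shown, and "the series" means these compounds.

Two macrocyclic compounds have been tested in an ADME assay on cells (Homo sapiens) for activation; a lower number here means that less compound is tolerated, a higher number that more compound is tolerated. Compound 1 `CCCn1cc(-c2cc(OCC[C@@H]3NC(=O)N(C)CCCC/C=C\[C@@H]4C[C@@]4(C(=O)NS(=O)(=O)C4(C)CC4)NC3=O)c3ccc(OC)c(C)c3n2)cn1` gives 62300 nM, while compound 2 `COc1ccc2c(OCC[C@@H]3NC(=O)N(C)CCCC/C=C\[C@@H]4C[C@@]4(C(=O)NS(=O)(=O)N4CCC[C@H]4C#N)NC3=O)cc(-c3nc(C(C)C)cs3)nc2c1Cl` gives 28300 nM, the lower of the two numbers, with compound 1 standing beyond the usual scatter above it. Compound 3 `C#CC1(S(=O)(=O)NC(=O)[C@@]23C[C@H]2/C=C\CCCCN(C)C(=O)N[C@@H](CCOc2cc(-c4nc(C(C)C)cs4)nc4c(Cl)c(OC)ccc24)C(=O)N3)CC1` keeps the core of compound 2 and changes only the group on the sulfonyl sulfur: 1-ethynylcyclopropyl in place of 2-cyanopyrrolidin-1-yl on a sulfonyl sulfur. For the measured compounds named here, with no matched pair to draw on, only a small step is expected, a 1.2-fold higher number from compound 2 to compound 3 (0.09 log units; within the scatter), within the scatter. Compound 3 is estimated at 35000 nM, between 15000 nM and 80000 nM.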

Compound 3, half-maximal cytotoxic concentration: 26300 nM
Compound 3: the middle estimate sits 1.3-fold (0.12 log units) above what was measured; the measured number falls inside the stated range.
By their numbers in this assay, from the lowest: compounds 3 and 2 (each within the scatter of the next); then compound 1.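

For the compounds shown here, putting 1-ethynylcyclopropyl in place of 2-cyanopyrrolidin-1-yl on the sulfonyl sulfur gives a 1.1-fold lower number from compound 2 to compound 3 (0.03 log units; within the scatter) in this assay, the first single-place comparison in this set. The two groups differ in ring size and in the ring nitrogen, yet compound 2 and compound 3 stay within the scatter of each other. Nothing on hand offers an explanation for this result. From the compounds shown here alone, whether a phenyl ring or a primary amine on the sulfonyl sulfur would stay as close remains open, as does whether this swap would read the same on the core of compound 1.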